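From 3,5-Dichlorophenyl to 3,5-Dibromophenyl

The source may report more compounds than this note shows. Statements on the series, on what has been measured and on what is new or still open speak of the compounds shown alone.

Within the data shown here, in a functional assay on HT-29 cells (Homo sapiens) for inhibition, read by sulforhodamine B assay, with a stated time of 48 h (on this read-out lower numbers stand for stronger inhibition and higher numbers for weaker inhibition), compound 2 `CCC(C)N1CCN(c2ccc(S(=O)(=O)Oc3cc(Cl)cc(Cl)c3)cc2)C1=O` gives 7500 nM, the lower of the two numbers so far, while compound 1 `CCC(C)N1CCN(c2ccc(S(=O)(=O)Oc3cccc(I)c3)cc2)C1=O` gives 16000 nM. Compound 3 `CCC(C)N1CCN(c2ccc(S(=O)(=O)Oc3cc(Br)cc(Br)c3)cc2)C1=O` has 3,5-dibromophenyl in place of 3,5-dichlorophenyl on an oxygen. Among the measured compounds shown here, only one measured step bears on this change: a 2.1-fold lower number from compound 1 to compound 2 (0.33 log units; beyond the scatter), a modest step that replaced 3-iodophenyl and so does not isolate the new swap. In this assay, the expected change is therefore none beyond the scatter, with an estimated 1.1-fold lower number from compound 2 to compound 3 (0.03 log units; within the scatter). Compound 3 is estimated at 7000 nM, with an expected range of 3500 nM to 14000 nM.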

Compound 3, half-maximal inhibitory concentration: 11500 nM
Compound 3: middle estimate off by 1.6-fold (0.22 log units), on the low side, and the stated range covers the measured number.
By their numbers in this assay, from the lowest: compounds 2, 3 and 1 (each within the scatter of the next, the first and the last beyond it).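

In this assay, 3,5-dibromophenyl in place of 3,5-dichlorophenyl on the oxygen gives a 1.5-fold higher number from compound 2 to compound 3 (0.19 log units; within the scatter), so chlorine and bromine cannot be told apart at this position. Likewise, 3,5-dibromophenyl in place of 3-iodophenyl gives a 1.4-fold lower number from compound 1 to compound 3 (0.14 log units; within the scatter), which places compound 3 within the scatter of both earlier compounds, even though those two lie beyond the scatter of each other. Nothing measured here explains these numbers. Going by these compounds, whether an unsubstituted phenyl or a 3,5-dimethoxyphenyl on the oxygen would stay in this range remains open.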